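The source may hold more compounds than are shown below. What is called first, only, known or untested is meant among the compounds shown, and "the series" means these compounds.

Three amines that share one core are compared in an ADME assay on MDCK cells (Canis lupus familiaris) for cytotoxicity, read by microscopy, with a stated time of 48 h; a lower number here means that less compound is tolerated, a higher number that more compound is tolerated. Compound 1 `CCCc1csc(CN[C@@H]2C[C@H]3C[C@@H]([C@H]2C)C3(C)C)c1` gives 12500 nM. Compound 2 `C[C@H]1[C@H](NCc2cccs2)C[C@H]2C[C@@H]1C2(C)C` gives 25000 nM, and compound 3 `CSc1ccc(CN[C@@H]2C[C@H]3C[C@@H]([C@H]2C)C3(C)C)s1` gives 25000 nM. Compound 2 thus shows the same number as compound 3, and these two together are the highest of the three numbers, while compound 1 stands slightly apart from them; the step of a 2.0-fold higher number from compound 1 to compound 2 (0.30 log units; within the scatter) and the step of no change at the digits printed from compound 2 to compound 3 (within the scatter) are both small enough to count as ordinary variation between repeated measurements.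

Compound 4 `Cc1csc(CN[C@@H]2C[C@H]3C[C@@H]([C@H]2C)C3(C)C)n1` has not yet been measured. It differs from compound 2 in one place: 4-methyl-1,3-thiazol-2-yl in place of thiophen-2-yl on a saturated chain carbon bound to an amine nitrogen. The two measured steps each altered only a group attached to the thiophen-2-yl ring and left the ring itself untouched, and neither moved the number beyond the scatter. No measured step exchanges the ring for a different one, so there is no direct precedent for this change, and the two steps that come nearest to it give no reason to expect a move in either direction. The estimate for compound 4 in this assay is therefore 25000 nM, with a range from 12500 nM to 50000 nM. The expected step of no change at the digits printed from compound 2 to compound 4 (within the scatter) is none beyond the scatter.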

Compound 4, minimum cytotoxic concentration: > 100000 nM
Compound 4: a limit, no number; the forecaster's own chance of this, stated with the estimate: 15%; middle value at least 4.0-fold (0.60 log units) from the limit.
By their numbers in this assay, from the lowest: compounds 1, 2 and 3 (each within the scatter of the next). At a limit, above all of these: compound 4.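

Compound 4 gives > 100000 nM in this assay, which is a limit of the assay and not a number, and the true size of the change therefore stays unread: the limit of > 100000 nM in this assay, at which 1 of the 4 values shown sits. Even so, the step of an at least 4.0-fold higher number from compound 2 to compound 4 (0.60 log units; beyond the scatter) is the first among the compounds shown to lie beyond the scatter, and it shows that the number can respond to what sits on a saturated chain carbon bound to an amine nitrogen. Compound 1 and compound 3, which keep the thiophen-2-yl ring and only carry propyl or methylsulfanyl on it, stay within the scatter of compound 2, whereas replacing that ring with 4-methyl-1,3-thiazol-2-yl takes the reading up to the limit.

This exchange brings in a ring nitrogen and a methyl group together, and the compounds shown cannot separate the two. On these data alone, how a plain 1,3-thiazol-2-yl ring without the methyl, a methyl-bearing thiophene or a six-membered phenyl ring would read at this place remains open, as does whether other groups on the thiazole ring would keep the reading at the limit.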